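Aryl sulfonate in place of acetate on the phenol oxygen

A few compounds are considered here, and "the series" means these few. Any claim that something is new, unique, unknown or untested is made for them only; others in the source may bear on it.

Measured so far in an assay on HEK293 cells for antagonist activity at P2X purinoceptor 7 (Homo sapiens), read by fluorescence, with a stated time of 2 h; a higher number here means a weaker inhibitor, a lower number a stronger inhibitor: compound 1 `O=C(Oc1ccc(-c2cncn2C2CCN(C(=O)c3ccc(Cl)c(C(F)(F)F)c3)CC2)cc1)c1cccc2cnccc12` gives > 10000 nM, a limit of the assay. Compound 2 `CC(=O)Oc1ccc(-c2cncn2C2CCN(C(=O)c3ccc(Cl)c(C(F)(F)F)c3)CC2)cc1` gives > 10000 nM, again a limit. Compound 3 `O=C(c1ccc(Cl)c(C(F)(F)F)c1)N1CCC(n2cncc2-c2ccc(OS(=O)(=O)c3cccc4ccccc34)cc2)CC1` gives 3520 nM.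

Compound 2 therefore stands at the limit of > 10000 nM in this assay, at which 2 of the 3 values shown sit, with no number of its own. Compound 4 `O=C(c1ccc(Cl)c(C(F)(F)F)c1)N1CCC(n2cncc2-c2ccc(OS(=O)(=O)c3cccc([N+](=O)[O-])c3)cc2)CC1` differs from it by (3-nitrophenyl)sulfonyl in place of acetyl on an oxygen on an aromatic ring. Among the measured compounds shown here, the one step measured at this oxygen, a step that the two limits leave unreadable from compound 1 to compound 2, runs between two limits and gives no size. For the measured compounds named here, the values of compound 2 and compound 3 show only that the naphthalenesulfonyl analogue reaches a number where the acetate does not. A step toward stronger inhibition is therefore expected, an at least 2.0-fold lower number from compound 2 to compound 4 (0.30 log units; that floor lies within the scatter), though its size is uncertain. Compound 4 is estimated at 5000 nM, within 1500 nM to 20000 nM.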

Compound 4, half-maximal inhibitory concentration: 249 nM
Estimate against measurement, compound 4: 20-fold (1.30 log units) above, and the stated range ends above it.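

Replacing the ester on the oxygen on an aromatic ring with the (3-nitrophenyl)sulfonyl group gives an at least 40-fold lower number from compound 2 to compound 4 (1.60 log units; beyond the scatter) and an at least 40-fold lower number from compound 1 to compound 4 (1.60 log units; beyond the scatter). Both steps are floors, since compound 1 and compound 2 each stand at a limit of the assay. The sulfonates also differ from each other, so the group on the sulfonyl sulfur matters, not the sulfonate link alone: a 14-fold lower number from compound 3 to compound 4 (1.15 log units; beyond the scatter).

Going by these compounds, it remains open whether an unsubstituted phenyl on the sulfonyl sulfur holds this level. The same applies to an amine or a carboxylic acid in place of the nitro group.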